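A few compounds are considered here, and "the series" means these few. Any claim that something is new, unique, unknown or untested is made for them only; others in the source may bear on it.

Working notes on the series in a functional assay on U2OS cells with metabotropic glutamate receptor 5 (Homo sapiens) as the target, read by calcium flux; a higher number here means a larger maximal response, a lower number a smaller maximal response. Two compounds are measured. Compound 1 `Fc1ccc(-c2noc(C3CCc4c(nnn4-c4ccc(F)cc4)C3)n2)cc1` reaches 106%. Within the data shown here, compound 2 `Fc1ccc(-c2noc(C3CCc4c(nnn4C4CCOC4)C3)n2)cc1` reaches 96%; the step of a number 10 percentage points lower from compound 1 to compound 2 (within the scatter) is within the scatter, so compound 2 stands alongside compound 1 on the numbers so far, with no separation beyond the usual spread of this assay.

Compound 3 `CC(C)n1nnc2c1CCC(c1nc(-c3ccc(F)cc3)no1)C2` is not yet measured. Relative to compound 2 the change is isopropyl in place of oxolan-3-yl on an aromatic nitrogen. Among the measured compounds shown here, the one measured step that bears on this position is the exchange at the same aromatic nitrogen, a number 10 percentage points lower from compound 1 to compound 2 (within the scatter), which did not move the maximal response beyond the scatter. On that basis the expectation for compound 3 in this assay is a step of a number 2 percentage points higher from compound 2 to compound 3 (within the scatter), that is, none beyond the scatter. The estimate for compound 3 is accordingly 98%, in a range from 82% to 114%.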

Compound 3, largest response reached (reported as percent of maximum), in percent of the reference or control that the assay uses: 98%
Estimate against measurement, compound 3: no gap at the digits printed, and the stated range covers the measured number.
By their numbers in this assay, from the lowest: compounds 2, 3 and 1 (each within the scatter of the next).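

In this assay the exchange for isopropyl gives a number 2 percentage points higher from compound 2 to compound 3 (within the scatter), and the same group set against 4-fluorophenyl gives a number 8 percentage points lower from compound 1 to compound 3 (within the scatter). The position on the aromatic nitrogen therefore now carries a group with no ring and no hydrogen-bond acceptor, alongside the two ring-bearing groups, with no separation in maximal response among the three. No independent measurement bears on why these exchanges leave the response unseparated.

Going by these compounds, all three groups carry no net charge and no hydrogen-bond donor, so whether a carboxylic acid, a primary amine or a longer alkyl chain on this nitrogen keeps the response in this assay remains open. The rest of the core is the same in all three compounds, so these numbers say nothing about changes elsewhere.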